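Thiophen-2-yl in place of 5-methylfuran-2-yl: working notes

The compounds below may be only part of what the source reports. "The series", "measured", "known", "first", "only" and "open" are said of these compounds alone.

- compound 1 `O=C(CCCCCCC(=O)Nc1nnc(-c2ccco2)s1)NO`: 880 nM
- compound 2 `Cc1ccc(-c2nnc(NC(=O)CCCCCCC(=O)NO)s2)o1`: 880 nM

In a functional assay on SW-620 cells (Homo sapiens) for inhibition, read by MTT assay (a higher number here means a weaker inhibitor, a lower number a stronger inhibitor), compound 2 gives 880 nM, level with compound 1. Compound 3 `O=C(CCCCCCC(=O)Nc1nnc(-c2cccs2)s1)NO` carries thiophen-2-yl in place of 5-methylfuran-2-yl on an aromatic carbon. Going by the values given here, only one measured step bears on this group, no change at the digits printed from compound 1 to compound 2 (within the scatter), and it shows that methyl in place of hydrogen left the value unmoved. Among the compounds with values here, no measured step exchanges the oxygen of this ring for sulfur, so that part of the change remains untested. Within the data shown here, with only that precedent, no shift beyond the scatter is expected, and the direction stays open. The estimated step is a 1.1-fold lower number from compound 2 to compound 3 (0.04 log units; within the scatter). Compound 3 is expected at 800 nM, with an estimated range of 350 nM to 1800 nM.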

Compound 3, half-maximal inhibitory concentration: 880 nM
Estimate against measurement, compound 3: 1.1-fold (0.04 log units) below; low and high end bracket the measured number.
By their numbers in this assay, from the lowest: compounds 1, 2 and 3 (each within the scatter of the next).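

In this assay the exchange reads no change at the digits printed from compound 2 to compound 3 (within the scatter) and the plain ring exchange, thiophen-2-yl in place of furan-2-yl, reads no change at the digits printed from compound 1 to compound 3 (within the scatter) as well. Sulfur for oxygen in this ring, untested by the earlier compounds, thus leaves the value unmoved on this aromatic carbon. Nothing measured accounts for this level result.

As far as these compounds go, all three groups here are five-membered aromatic rings with one hetero atom, so it stays open whether a phenyl ring or an amine at this place would shift the value. From the compounds shown here alone, the effect of a longer chain also stays open.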